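Swapping the Cyclic Amine Substituent in a Channel Antagonist Series

The source may report more compounds than this note shows. Statements on the series, on what has been measured and on what is new or still open speak of the compounds shown alone.

Of the compounds shown here, three built on one shared core have so far been measured in a functional assay on CHO-K1 cells for antagonist activity at transient receptor potential cation channel subfamily V member 1 (Homo sapiens), read by FLIPR; on this read-out higher numbers stand for weaker inhibition and lower numbers for stronger inhibition. Compound 1 `CCCCN(C)c1nc(C(F)(F)F)ccc1CNC(=O)C(C)c1ccc(NS(C)(=O)=O)c(F)c1` gives 21.3 nM, compound 2 `CC(C(=O)NCc1ccc(C(F)(F)F)nc1N(C)c1ccccc1)c1ccc(NS(C)(=O)=O)c(F)c1` gives 57.4 nM, and compound 3 `CC(C(=O)NCc1ccc(C(F)(F)F)nc1N1CCC(C(F)(F)F)CC1)c1ccc(NS(C)(=O)=O)c(F)c1` gives 31 nM. Among these three numbers compound 3 stands second highest: its nearest neighbour is compound 1, the gap being a 1.5-fold higher number from compound 1 to compound 3 (0.16 log units; within the scatter), and its furthest is compound 2, with a 1.9-fold lower number from compound 2 to compound 3 (0.27 log units; within the scatter). Only the exchange of the butyl chain for a phenyl ring separates the two flanking compounds, and that step, a 2.7-fold higher number from compound 1 to compound 2 (0.43 log units; beyond the scatter), is the single one in the set that reaches beyond the scatter.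

Compound 4 `CC(C(=O)NCc1ccc(C(F)(F)F)nc1N1CCCCCCC1)c1ccc(NS(C)(=O)=O)c(F)c1` differs from compound 3 in one place: a group of 8 heavy atoms (7 carbon, 1 nitrogen; one eight-membered non-aromatic ring with 1 hetero atom) in place of a group of 10 heavy atoms (6 carbon, 1 nitrogen, 3 fluorine; one six-membered non-aromatic ring with 1 hetero atom), on an aromatic carbon. For the measured compounds named here, no measured step exchanges one saturated ring for another of a different size, so none of the three bears on this change directly. What the measured steps do show is that the substituent at this position has accepted an open chain, an aryl group and a fluorinated ring with, at most, modest movement. For compound 4 a step of a 1.1-fold higher number from compound 3 to compound 4 (0.05 log units; within the scatter) is therefore expected, which is to say no change beyond the scatter. Compound 4 is estimated at 35 nM, with a range from 15 nM to 85 nM, in this assay.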

Compound 4, half-maximal inhibitory concentration: 27.8 nM
Beside the measured number, compound 4's estimate is 1.3-fold (0.10 log units) above it; low and high end bracket the measured number.
By their numbers in this assay, from the lowest: compounds 1, 4, 3 and 2 (each within the scatter of the next, the first and the last beyond it).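

In this assay, the eight-membered ring proves as acceptable at this position as the 4-(trifluoromethyl)piperidin-1-yl and butyl(methyl)amino groups, with no separation from either (a 1.1-fold lower number from compound 3 to compound 4 (0.05 log units; within the scatter); a 1.3-fold higher number from compound 1 to compound 4 (0.12 log units; within the scatter)). The exchange for the methyl(phenyl)amino group of compound 2, however, gives a step beyond the scatter, though a modest one (a 2.1-fold lower number from compound 2 to compound 4 (0.31 log units; beyond the scatter)), so both compound 1 and compound 4 now stand apart from compound 2, whereas compound 3, which goes against this pattern, remains within the scatter of compound 2. Since the step from compound 3 to compound 4 enlarges the ring and removes the trifluoromethyl group together, it cannot separate the two changes, and no supporting measurement explains the values that were found.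

The compounds shown leave open how an unsubstituted piperidine or a seven-membered azepane would compare, either of which would help to separate ring size from the trifluoromethyl group. Also open, on these data alone, is whether a morpholine, a piperazine, or a group attached through oxygen, such as butoxy, would be accepted here as the nitrogen-linked groups are.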